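Aryl urea variation on the shared quinoline ether core

A few compounds are considered here, and "the series" means these few. Any claim that something is new, unique, unknown or untested is made for them only; others in the source may bear on it.

Compound 3 `COc1cc2c(Oc3ccc(/C=N/NC(=O)Nc4ccc(Br)cc4)cc3F)ccnc2cc1OCCCN1CCCCC1` gives 60 nM in a functional assay on MKN-45 cells (Homo sapiens) for cytotoxicity, read by MTT assay, with a stated time of 72 h (on this read-out lower numbers stand for stronger inhibition and higher numbers for weaker inhibition), the lowest of the three numbers: compound 1 `COc1cc2c(Oc3ccc(/C=N/NC(=O)Nc4ccccc4)cc3F)ccnc2cc1OCCCN1CCCCC1` gives 180 nM and compound 2 `COc1cc2c(Oc3ccc(/C=N/NC(=O)Nc4ccc(F)c(F)c4)cc3F)ccnc2cc1OCCCN1CCCCC1` gives 320 nM. Compound 4 `COc1cc2c(Oc3ccc(/C=N/NC(=O)Nc4ccc(F)cc4Br)cc3F)ccnc2cc1OCCCN1CCCCC1` differs from compound 3 by 2-bromo-4-fluorophenyl in place of 4-bromophenyl on an amide-type nitrogen. The bearing steps are a 3.0-fold lower number from compound 1 to compound 3 (0.48 log units; beyond the scatter), a 1.8-fold higher number from compound 1 to compound 2 (0.25 log units; within the scatter) and a 5.3-fold lower number from compound 2 to compound 3 (0.73 log units; beyond the scatter). Within the data shown here, no measured pair tests the 2-bromo-4-fluorophenyl pattern itself; the bromo is retained, the added fluorine on the ring recalls compound 2, where fluorines gave no step beyond the scatter. Compound 4 is therefore expected near compound 3, with a small step of a 1.8-fold higher number from compound 3 to compound 4 (0.26 log units; within the scatter). The estimate for compound 4 is 110 nM, range 40 nM to 350 nM.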

Compound 4, half-maximal inhibitory concentration: 140 nM
Estimate against measurement, compound 4: 1.3-fold (0.10 log units) below, within the range that was stated.
By their numbers in this assay, from the lowest: compound 3; then compounds 4, 1 and 2 (each within the scatter of the next, the first and the last beyond it).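

On the amide-type nitrogen, 2-bromo-4-fluorophenyl in place of 4-bromophenyl gives a step beyond the scatter in this assay (a 2.3-fold higher number from compound 3 to compound 4 (0.37 log units; beyond the scatter)), so keeping a bromo on the ring does not alone preserve the number of compound 3. The same group separates from 3,4-difluorophenyl (a 2.3-fold lower number from compound 2 to compound 4 (0.36 log units; beyond the scatter)) but not from plain phenyl (a 1.3-fold lower number from compound 1 to compound 4 (0.11 log units; within the scatter)). No measurement here explains these steps.

Open: whether the step from compound 3 follows the added fluorine or the change from 4-bromo to 2-bromo, and how a methoxy group or an amine on this phenyl would read.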